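Swapping 4-Aminophenyl for 2-Fluorophenyl in a Cytotoxicity Assay

The source may report more compounds than this note shows. Statements on the series, on what has been measured and on what is new or still open speak of the compounds shown alone.

In an ADME assay on BJ cells (Homo sapiens) for cytotoxicity, with a stated time of 72 h (a higher number here means that more compound is needed for the effect, a lower number that less compound is needed), compound 1 (`Cc1cc(NC(=O)Nc2ccccc2C(C)(C)C)c2ccccc2n1`) gives 22000 nM. Compound 2 (`Cc1cc(NC(=O)Nc2ccc(N)cc2)c2ccccc2n1`) gives > 25000 nM, which is a limit of the assay and not a number. Compound 3 (`Cc1cc(NC(=O)Nc2ccccc2F)c2ccccc2n1`) has 2-fluorophenyl in place of 4-aminophenyl on an amide-type nitrogen. Within the data shown here, no measured step between compounds is available to guide the expectation. Compound 1 shows that a measurable value can occur at 22000 nM, so compound 3 is expected to sit in the same region. The expected change, an at least 1.0-fold lower number from compound 2 to compound 3 (0.01 log units; that floor lies within the scatter), is a small one, not beyond the usual scatter. For compound 3 the estimated value is 24000 nM, with an expected range of 12000 nM to 40000 nM.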

Compound 3, half-maximal effective concentration: > 25000 nM
Compound 3 gave a limit, no number; the forecaster's own chance of this, stated with the estimate: 65%; middle value at least 1.0-fold (0.01 log units) from the limit.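

In this assay, compound 3 and compound 2 each give only a limit, so the step between them cannot be read. Fluoro in place of tert-butyl on an aromatic carbon gives an at least 1.1-fold higher number from compound 1 to compound 3 (0.05 log units; that floor lies within the scatter), which is only a floor, so its true size stays unknown. On an amide-type nitrogen, 2-fluorophenyl and 4-aminophenyl both end at the same limit of the assay: the limit of > 25000 nM in this assay, at which 2 of the 3 values shown sit.

Going by these compounds, it remains open how far beyond this limit the true values of compound 2 and compound 3 lie. On these data alone, it also remains open whether a carboxylic acid or a longer chain on this nitrogen would give a measurable value.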